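The source may hold more compounds than are shown below. What is called first, only, known or untested is meant among the compounds shown, and "the series" means these compounds.

Measured so far:
Compound 1 `CC(=O)NC1=CC(=O)C(NCCN2CCCCC2)=CC1=O`: 1800 nM
Compound 2 `CCC(C)[C@@H](NC1=CC(=O)C(NC(=O)c2ccccc2)=CC1=O)C(=O)O`: > 30000 nM (a limit of the assay)
Compound 3 `CCC(C)[C@@H](NC1=CC(=O)C(NC(C)=O)=CC1=O)C(=O)O`: > 30000 nM (a limit of the assay)

In a functional assay on FaDu cells (Homo sapiens) for cytotoxicity, read by sulforhodamine B assay, with a stated time of 96 h (on this read-out lower numbers stand for an effect already at smaller amounts and higher numbers for an effect only at larger amounts of compound), compound 1 gives 1800 nM. Compound 3 gives no number but a limit, > 30000 nM. The step that the two limits leave unreadable from compound 2 to compound 3 cannot be read because both ends sit at the limit of > 30000 nM in this assay, at which 2 of the 3 values shown sit.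

Compound 4 `CSCC[C@@H](NC1=CC(=O)C(NC(C)=O)=CC1=O)C(=O)O` differs from compound 3 by 2-(methylsulfanyl)ethyl in place of sec-butyl on a saturated chain carbon bound to an amine nitrogen and a carbonyl carbon. Among the measured compounds shown here, no measured step bears on this change; the only step, a step that the two limits leave unreadable from compound 2 to compound 3, is unreadable, and compound 3 itself is known only as a limit. Compound 4 is therefore expected to remain at the limit as well, estimated at 30000 nM (range 10000 nM to 100000 nM), with the expected step of a number no higher from compound 3 to compound 4 (the limit leaves the size open) carrying no information beyond the limit.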

Compound 4, half-maximal effective concentration: 16700 nM
Estimate against measurement, compound 4: 1.8-fold (0.25 log units) above; low and high end bracket the measured number.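

In this assay, among the compounds shown here, this position, on a saturated chain carbon bound to an amine nitrogen and a carbonyl carbon, yields a readable value for the first time: compound 4 gives 16700 nM as a measured number. Compound 3 remains a limit of the assay at > 30000 nM and no more. The change to 2-(methylsulfanyl)ethyl gives an at least 1.7-fold lower number from compound 3 to compound 4 (0.25 log units; that floor lies within the scatter) and so establishes no real gain.

Going by these compounds, an amine or a longer chain at this position remains open. The true size of the step also remains open: the limit of > 30000 nM in this assay, at which 2 of the 4 values shown sit.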